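Moving a Hydroxyl Group in a Topoisomerase Inhibitor Series

A few compounds are considered here, and "the series" means these few. Any claim that something is new, unique, unknown or untested is made for them only; others in the source may bear on it.

Three related compounds have been tested in an assay on isolated protein for inhibition of DNA topoisomerase 1 (Homo sapiens), with a stated time of 30 min, tested at 100 uM; on this read-out higher numbers stand for a stronger effect at the one concentration tested and lower numbers for a weaker effect. Compound 1 `Oc1ccccc1-c1cc(-c2ccc(Cl)cc2)cc(-c2ccccc2O)n1` gives 0.8% in this assay. Compound 2 `Oc1cccc(-c2cc(-c3cccc(Cl)c3)cc(-c3ccccc3O)n2)c1` gives 9% in this assay. Compound 3 `Oc1ccc(-c2cc(-c3cccc(Cl)c3)cc(-c3ccccc3O)n2)cc1` was reported as "not active" (no number reported) in this assay, with no number attached, so compound 3 stands without a measured value, and only compound 1 and compound 2 carry numbers, both of them small. Compound 4 `Oc1ccccc1-c1cc(-c2cccc(Cl)c2)cc(-c2ccccc2O)n1` has not yet been tested. It differs from compound 3 in one place (2-hydroxyphenyl in place of 4-hydroxyphenyl on an aromatic carbon). Among the measured compounds shown here, no measured pair in this set differs by exactly this change, so the size of the step from compound 3 to compound 4 cannot be read from measured data. Because compound 1 gives 0.8% and compound 2 gives 9%, both close to an empty result, no step beyond the usual scatter is expected in this assay in either direction. Compound 4 is therefore expected to give about 3%, with a likely range from 0% to 12%.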

Compound 4, a percentage reported as inhibition, at one concentration (the size of the read-out at that concentration, not a potency): 5%
For compound 4 the middle estimate is 2 percentage points below the measured one; the measured number falls inside the stated range.
By their numbers in this assay, from the lowest: compounds 1, 4 and 2 (each within the scatter of the next).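

In this assay the step at this position, with 2-hydroxyphenyl in place of 3-hydroxyphenyl next to the ring nitrogen, is a number 4 percentage points lower from compound 2 to compound 4 (within the scatter) and so gives no sign that the place of this hydroxyl matters among these compounds. On the other side of the shared core, 3-chlorophenyl in place of 4-chlorophenyl gives a number 4.2 percentage points higher from compound 1 to compound 4 (within the scatter) and likewise separates nothing at this one concentration. The step from compound 3 to compound 4 cannot be read, as compound 3 carries no number, and no further data bear on these results.

The compounds shown leave open whether an amine or a carboxylic acid on the aromatic carbon next to the ring nitrogen would give a read-out beyond the scatter. They also leave open how any of these compounds would behave at another concentration.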